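The source may hold more compounds than are shown below. What is called first, only, known or untested is meant among the compounds shown, and "the series" means these compounds.

Compound 2 `Nc1nn(C(=O)Nc2ccc(Cc3ccccc3)cc2)c2ccc(Cl)cc12` stands at the edge of what a functional assay on CAKI-1 cells (Homo sapiens) for antiproliferative activity, read by sulforhodamine B assay, with a stated time of 48 h (a lower number here means that less compound is tolerated, a higher number that more compound is tolerated), can report: compound 2 gives > 100000 nM, which is a limit of the assay and not a number. Compound 1 `Nc1nn(C(=O)Nc2ccc(Cc3ccccc3)cc2)c2ccccc12` also gives only a limit in this assay, namely > 100000 nM. The step that the two limits leave unreadable from compound 1 to compound 2 therefore cannot be sized, since both values sit at the limit of > 100000 nM in this assay, at which 2 of the 2 values shown sit. Compound 3 `Nc1ccc2c(c1)c(N)nn2C(=O)Nc1ccc(Cc2ccccc2)cc1` differs from compound 2 by amino in place of chloro on an aromatic carbon. No readable measured step bears on this change, so no shift beyond the scatter is expected. Compound 3 is expected to give about 150000 nM, within 60000 nM to 400000 nM. The expected step is a step that the limit leaves unreadable from compound 2 to compound 3.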

Compound 3, concentration lethal to 50% of the cells: > 100000 nM
Compound 3 ended at the assay's limit; the forecaster's own chance of this, stated with the estimate: 70%; the middle value lies beyond the limit too.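

No step can be read among compound 1, compound 2 and compound 3, since all three stop at the assay's limit: the limit of > 100000 nM in this assay, at which 3 of the 3 values shown sit.

Going by these compounds, whether hydrogen, chloro or amino on the aromatic carbon changes the lethal concentration in this assay stays open.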